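Methoxy for Iodo on the Aryl Tail of Compound 3

The compounds below may be only part of what the source reports. "The series", "measured", "known", "first", "only" and "open" are said of these compounds alone.

Compound 3 `O=c1[nH]/c(=N\OCCCc2ccc(I)cc2)ccn1[C@@H]1O[C@H](COP(=O)(O)OP(=O)(O)OP(=O)(O)O)[C@@H](O)[C@H]1O` holds the lowest number of the three measured compounds in a functional assay on 1321-N1 cells for agonist activity at P2Y purinoceptor 6 (Homo sapiens), read by scintillation counting and inositol phosphate accumulation (on this read-out higher numbers stand for an effect only at larger amounts of compound and lower numbers for an effect already at smaller amounts), giving 90 nM. Compound 2 `O=c1[nH]/c(=N\OCCCc2cccc(F)c2)ccn1[C@@H]1O[C@H](COP(=O)(O)OP(=O)(O)OP(=O)(O)O)[C@@H](O)[C@H]1O` gives 539 nM and compound 1 `O=c1[nH]/c(=N\OCCOc2ccccc2)ccn1[C@@H]1O[C@H](COP(=O)(O)OP(=O)(O)OP(=O)(O)O)[C@@H](O)[C@H]1O` gives 1780 nM; the step of a 6.0-fold lower number from compound 2 to compound 3 (0.78 log units; beyond the scatter) and the step of a 20-fold lower number from compound 1 to compound 3 (1.30 log units; beyond the scatter) both run toward compound 3. Compound 4 `COc1ccc(CCCO/N=c2/ccn([C@@H]3O[C@H](COP(=O)(O)OP(=O)(O)OP(=O)(O)O)[C@@H](O)[C@H]3O)c(=O)[nH]2)cc1` differs from compound 3 by methoxy in place of iodo on an aromatic carbon, on an aromatic carbon of a six-membered aromatic ring of carbon only, para to a large group. Within the data shown here, no measured step exchanges a group at that same carbon, and the nearest comparison, a 6.0-fold lower number from compound 2 to compound 3 (0.78 log units; beyond the scatter), did not involve a methoxy group. A modest rise in the number is therefore expected for compound 4, a 2.8-fold higher number from compound 3 to compound 4 (0.44 log units; beyond the scatter). Compound 4 is estimated at 250 nM, with a range from 90 nM to 700 nM.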

Compound 4, half-maximal effective concentration: 277 nM
Compound 4: the middle estimate sits 1.1-fold (0.04 log units) below what was measured; low and high end bracket the measured number.
By their numbers in this assay, from the lowest: compound 3; then compounds 4 and 2 (each within the scatter of the next); then compound 1.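

In this assay, the only exchange shown on this aromatic carbon gives up part of what iodo held there (a 3.1-fold higher number from compound 3 to compound 4 (0.49 log units; beyond the scatter)), so methoxy does not simply stand in for iodo at this position. The 4-methoxyphenyl and 3-fluorophenyl tails cannot be told apart (a 1.9-fold lower number from compound 2 to compound 4 (0.29 log units; within the scatter)), while the 4-methoxybenzyl tail keeps a clear gap to phenoxy (a 6.4-fold lower number from compound 1 to compound 4 (0.81 log units; beyond the scatter)). Nothing measured here accounts for the gap between iodo and methoxy. From the compounds shown here alone, whether bromo or chloro on this carbon would stay closer to compound 3 remains open, as does the outcome with ethoxy, hydroxy or an amine there.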